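Anilide variation on a shared core: limits throughout

The source may report more compounds than this note shows. Statements on the series, on what has been measured and on what is new or still open speak of the compounds shown alone.

Compound 1 `O=C(Cn1c(=O)c(/C=C\c2ccncc2)nc2ccccc21)Nc1ccccc1` is the parent of this set. In a functional assay on MCF7 cells (Homo sapiens) for inhibition, read by MTT assay, with a stated time of 24 h (a lower number here means a stronger inhibitor, a higher number a weaker inhibitor), compound 1 gives > 100000 nM, a limit of the assay rather than a number. Compound 2 `O=C(Cn1c(=O)c(/C=C\c2ccncc2)nc2ccccc21)Nc1ccc(Cl)cc1` gives > 100000 nM, again a limit. Compound 3 `Cc1ccccc1NC(=O)Cn1c(=O)c(/C=C\c2ccncc2)nc2ccccc21` gives > 100000 nM, also a limit. Going by the values given here, the steps a step that the two limits leave unreadable from compound 1 to compound 2 and a step that the two limits leave unreadable from compound 1 to compound 3 are therefore unreadable, and the limit of > 100000 nM in this assay, at which 3 of the 3 values shown sit, covers every value so far. Compound 4 `COc1ccc(NC(=O)Cn2c(=O)c(/C=C\c3ccncc3)nc3ccccc32)cc1OC` carries the change (3,4-dimethoxyphenyl in place of phenyl on an amide-type nitrogen). Among the compounds with values here, no measured step bears on it in a readable way, so no direction can be set. The expectation is that compound 4 also sits at the limit, with a step that the limit leaves unreadable from compound 1 to compound 4 not readable beyond scatter. The estimate for compound 4 is 150000 nM, between 40000 nM and 600000 nM.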

Compound 4, half-maximal inhibitory concentration: > 100000 nM
Compound 4 was reported as a limit; the forecaster's own chance of this, stated with the estimate: 85%; the middle value lies beyond the limit too.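

Going by these compounds alone, no step from compound 1, compound 2 or compound 3 to compound 4 can be read, since all four values are limits: the limit of > 100000 nM in this assay, at which 4 of the 4 values shown sit. The compounds shown leave open whether any group on the amide-type nitrogen of the shared core gives a measurable value in this assay.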